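This account rests on a few compounds, and the source may have more. Where it says the series, first, only, none or still open, it means among the compounds named here.

Compound 1 `CC1=NC(C)=C(C(=O)O)C(c2cccc(Cl)c2)/C1=C(\O)OC/C=C/c1ccccc1` and compound 2 `CC1=NC(C)=C(C(=O)O)C(c2cccc(Cl)c2)/C1=C(\O)OC/C=C/c1ccc(C)cc1` share one core and differ only at the aromatic ring at the end of the chain. In a functional assay on IMR-32 cells for inhibition of Voltage-dependent N-type calcium channel subunit alpha-1B (Homo sapiens), read by calcium flux (a higher number here means a weaker inhibitor, a lower number a stronger inhibitor), compound 1 gives 1000 nM, and compound 2 gives 890 nM; the step of a 1.1-fold lower number from compound 1 to compound 2 (0.05 log units; within the scatter) is small. Among the two numbers, compound 2 holds the lowest one, with compound 1 nearest and within the scatter of it. Compound 3 `CC1=NC(C)=C(C(=O)O)C(c2cccc(Cl)c2)/C1=C(\O)OC/C=C/c1ccncc1` carries a further change at that same ring: pyridin-4-yl in place of 4-methylphenyl on a double-bonded chain carbon bound to a double-bonded chain carbon. Within the data shown here, the only measured step, a 1.1-fold lower number from compound 1 to compound 2 (0.05 log units; within the scatter), concerns a substituent on that ring and lies within the scatter; no measured pair exchanges a ring carbon for a ring nitrogen, so the size of such an exchange in this assay is unknown here. For compound 3 a small step is expected, a 1.2-fold higher number from compound 2 to compound 3 (0.09 log units; within the scatter), with wide uncertainty. Compound 3 is estimated in this assay at 1100 nM, between 450 nM and 2800 nM.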

Compound 3, half-maximal inhibitory concentration: 6200 nM
For compound 3 the middle estimate is 5.6-fold (0.75 log units) below the measured one; the measured number lies above the stated range.
By their numbers in this assay, from the lowest: compounds 2 and 1 (each within the scatter of the next); then compound 3.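

In this assay the exchange of a carbon-only ring for pyridin-4-yl on a double-bonded chain carbon bound to a double-bonded chain carbon gives a 7.0-fold higher number from compound 2 to compound 3 (0.84 log units; beyond the scatter) and likewise a 6.2-fold higher number from compound 1 to compound 3 (0.79 log units; beyond the scatter) in the unsubstituted pair. Among these compounds, until now the only change at this ring, the added methyl, had stayed within the scatter, so this result is the first sign that the number responds to what stands at the end of the chain, and that the response is to a change in the ring itself and goes toward weaker inhibition. Nothing available here bears on why the number rises.

The compounds shown leave open whether pyridin-3-yl or pyridin-2-yl would give a number like that of compound 3 or like that of compound 2. They also leave open whether 4-aminophenyl or 4-hydroxyphenyl at the same place would move the number in the same direction.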